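Methyl on the phenyl ring: compound 3 to compound 4

This account rests on a few compounds, and the source may have more. Where it says the series, first, only, none or still open, it means among the compounds named here.

Values in an ADME assay on MDBK cells (Bos taurus) for cytotoxicity, read by MTT assay, with a stated time of 72 h; a higher number here means that more compound is tolerated, a lower number that less compound is tolerated:
- compound 1 `FC(F)(F)c1ccc(NCc2cn(-c3ccccc3)nc2-c2ccc(Br)cc2)cc1`: 46000 nM
- compound 2 `Cc1ccc(NCc2cn(-c3ccccc3)nc2-c2ccc(C)cc2)cc1`: > 100000 nM (a limit of the assay)
- compound 3 `FC(F)(F)c1ccc(NCc2cn(-c3ccccc3)nc2-c2ccccc2)cc1`: 34000 nM

Within the data shown here, compound 3 sits within the scatter of compound 1, the only other actual number in the set. The entry for compound 2 is a limit.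

The next analogue, compound 4 `Cc1ccc(-c2nn(-c3ccccc3)cc2CNc2ccc(C(F)(F)F)cc2)cc1`, carries methyl in place of hydrogen on an aromatic carbon, para to a large group: methyl in place of hydrogen on an aromatic carbon.

Among the measured compounds shown here, the one measured step on that carbon, a 1.4-fold lower number from compound 1 to compound 3 (0.13 log units; within the scatter), is hydrogen in place of bromo. On that evidence, no step beyond the scatter is expected in this assay. The expected step is a 1.1-fold higher number from compound 3 to compound 4 (0.05 log units; within the scatter).

Compound 4 is estimated at 38000 nM, with an expected range of 18000 nM to 80000 nM.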

Compound 4, half-maximal cytotoxic concentration: > 100000 nM
Compound 4 was reported as a limit (the forecaster's own chance of this, stated with the estimate: 8%); at least 2.6-fold (0.42 log units) between middle value and limit.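

In this assay, this carbon, para to a large group, now shows a change beyond the scatter: methyl in place of hydrogen gives an at least 2.9-fold higher number from compound 3 to compound 4 (0.46 log units; beyond the scatter), and methyl in place of bromo gives an at least 2.1-fold higher number from compound 1 to compound 4 (0.33 log units; beyond the scatter). Hydrogen and bromo did not separate at this position, so methyl is the first group here to stand apart from both. Compound 4 is reported as a limit, and both steps give only a minimum size: the limit of > 100000 nM in this assay, at which 2 of the 4 values shown sit.

The step between the two limits, trifluoromethyl in place of methyl, cannot be read. As far as these compounds go, whether ethyl, methoxy or an amine on this carbon would track with methyl, or with hydrogen and bromo, remains open.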